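Removing a Methyl Group: From Compound 2 to Compound 3

A few compounds are considered here, and "the series" means these few. Any claim that something is new, unique, unknown or untested is made for them only; others in the source may bear on it.

Measured compounds:
- compound 1, `O=C(CCC1C(=O)N(c2ccc(Cl)cc2)C(=O)N1Cc1ccc(Br)cc1)Nc1ccc(C(=O)NO)cc1`: 9.7 nM
- compound 2, `Cc1ccc(CN2C(=O)N(c3ccc(Cl)cc3)C(=O)C2CCC(=O)Nc2ccc(C(=O)NO)cc2)cc1`: 4.4 nM

Both compounds were tested in an assay on isolated protein for inhibition of protein deacetylase HDAC6 (Homo sapiens), read by fluorescence, with stated times of 5 min and 60 min; on this read-out higher numbers stand for weaker inhibition and lower numbers for stronger inhibition. Compound 1 gives 9.7 nM in this assay, and compound 2 gives 4.4 nM. Going by the values given here, compound 2 therefore has the lowest number of the two, and the only step available, a 2.2-fold lower number from compound 1 to compound 2 (0.34 log units; beyond the scatter), is modest but beyond the scatter. The two compounds share the same core and differ only in the group on one aromatic carbon of the benzyl ring: bromo in compound 1, methyl in compound 2.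

Compound 3, `O=C(CCC1C(=O)N(c2ccc(Cl)cc2)C(=O)N1Cc1ccccc1)Nc1ccc(C(=O)NO)cc1`, has not been measured. It differs from compound 2 by hydrogen in place of methyl on an aromatic carbon, so the substituted ring becomes a plain phenyl. The step from compound 1 to compound 2 is the only one that speaks to this position, and it shows that swapping the group there moves the number only modestly. Removing the group altogether is expected to shift the number by a similar modest amount, most likely upward, giving a 1.8-fold higher number from compound 2 to compound 3 (0.26 log units; within the scatter). Compound 3 is therefore estimated at 8 nM, with a range from 3.5 nM to 18 nM.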

Compound 3, half-maximal inhibitory concentration: 7.6 nM
Compound 3: the middle estimate sits 1.1-fold (0.02 log units) above what was measured; the range from low to high includes it.
By their numbers in this assay, from the lowest: compounds 2, 3 and 1 (each within the scatter of the next, the first and the last beyond it).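

In this assay, hydrogen in place of methyl gives a 1.7-fold higher number from compound 2 to compound 3 (0.24 log units; within the scatter), and hydrogen in place of bromo gives a 1.3-fold lower number from compound 1 to compound 3 (0.11 log units; within the scatter), so the compound with the plain benzyl group cannot be told apart from either of the substituted compounds. Going by these compounds alone, the earlier pair showed only that one group could be exchanged for another at this ring position, whereas this result shows that inhibition stays at a similar level with no heavy atom there at all, leaving the gap between methyl and bromo as the only difference beyond the scatter. No evidence is available to explain why these three numbers lie so close together.

The compounds shown leave open whether a larger or very different group at the same place, such as a methoxy, an amine, a carboxylic acid or a longer carbon chain, would keep the number this close or move it clearly. They also leave open whether methyl and hydrogen would remain this close if the chlorine on the other aromatic ring were replaced by another group, such as a methoxy.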